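One Enantiomer of a Racemate Seen Only at the Limit

The source may hold more compounds than are shown below. What is called first, only, known or untested is meant among the compounds shown, and "the series" means these compounds.

Compound 1 `Nc1cc(-c2cc(Cl)cc3c2OC(C(=O)N2CCNCC2)C3)ccn1` reaches only a limit in an assay on isolated protein for inhibition of ubiquitin carboxyl-terminal hydrolase 47 (Homo sapiens); a higher number here means a weaker inhibitor, a lower number a stronger inhibitor: > 80000 nM.
Compound 2 `O=C([C@H]1Cc2cc(Cl)cc(-c3ccnc4ccsc34)c2O1)N1CCNCC1` likewise reaches only a limit in this assay: > 40000 nM.
Compound 3 `O=C(C1Cc2cc(Cl)cc(-c3ccnc4[nH]ccc34)c2O1)N1CCNCC1` also reaches only a limit in this assay: > 80000 nM.

Compound 3 therefore stands at the top of the numbers, where every value shown is a limit: one sits at the limit of > 40000 nM in this assay, at which 1 of the 3 values shown sits, and two at the limit of > 80000 nM in this assay, at which 2 of the 3 values shown sit. Within the data shown here, the one single-point step among them, a step that the two limits leave unreadable from compound 1 to compound 3, cannot be read. Compound 4 `O=C([C@H]1Cc2cc(Cl)cc(-c3ccnc4[nH]ccc34)c2O1)N1CCNCC1` differs from compound 3 only in how it is drawn: the two compounds have the same atoms and bonds; at least one stereo element is drawn with a configuration in one of them and without one in the other: 1 of 1 stereo elements differ; a stereocentre at a saturated ring carbon is drawn without a configuration in compound 3 and R in compound 4. Among the measured compounds shown here, no measured step touches a stereochemical change, so nothing here argues for a shift beyond the scatter in this assay. Compound 4 is expected to stay at the limit, estimated at 80000 nM within 30000 nM to 200000 nM, so the expected step is a number no higher from compound 3 to compound 4 (the limit leaves the size open).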

Compound 4, half-maximal inhibitory concentration: > 80000 nM
Compound 4 gave a limit, no number; the forecaster's own chance of this, stated with the estimate: 85%; the middle value lies on the limit itself.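

In this assay compound 4 gives > 80000 nM, a limit, so its steps from compound 3 and from compound 2 cannot be read. The compounds shown leave open whether the drawn configuration or the aromatic group affects inhibition at all.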